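The source may report more compounds than this note shows. Statements on the series, on what has been measured and on what is new or still open speak of the compounds shown alone.

Series of hydroxy-amide esters, all measured in an ADME assay on HEK293 cells (Homo sapiens) for inhibition, read by CellTiter-Glo, with a stated time of 96 h, tested at 100 uM; on this read-out lower numbers stand for less inhibition and higher numbers for more inhibition at the one concentration tested (going by the name of the read-out). Compound 1 `CCOC(=O)/C=C/NC(=O)[C@H](O)C(C)(C)CO` gives -5%; compound 2 `CC(C)(C)OC(=O)/C=C\NC(=O)[C@H](O)C(C)(C)CO` gives -9%; compound 3 `CC(C)(CO)[C@@H](O)C(=O)N/C=C\C(=O)OCc1ccccc1` gives 7%, the highest of the three numbers, with compound 1 and compound 2 both lower, in each case beyond the scatter. Within the data shown here, the one step on record, a number 16 percentage points higher from compound 2 to compound 3 (beyond the scatter), is the only change of the ester group so far, and it is modest.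

Compound 4 `CCOC(=O)/C=C\NC(=O)[C@H](O)C(C)(C)CO` is the next member. methyl in place of phenyl on a saturated chain carbon bound to an oxygen next to a carbonyl group Relative to compound 3 this removes the aromatic ester group, the same kind of change that in compound 3 had gone the other way in a number 16 percentage points higher from compound 2 to compound 3 (beyond the scatter). Neither of the small esters, compound 1 or compound 2, rose above zero in this assay. A step downward of roughly the same size as that earlier step is therefore expected, so for compound 4 the estimate is a number 11 percentage points lower from compound 3 to compound 4 (beyond the scatter), putting compound 4 at -4% with a range of -16% to 8%.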

Compound 4, a percentage reported as inhibition, at one concentration (the size of the read-out at that concentration, not a potency): -6%
Estimate against measurement, compound 4: 2 percentage points above; low and high end bracket the measured number.
By their numbers in this assay, from the lowest: compounds 2, 4 and 1 (each within the scatter of the next); then compound 3.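

In this assay, the new step places the benzyl ester apart from the ethyl ester: a number 13 percentage points lower from compound 3 to compound 4 (beyond the scatter), and this is a second step of modest size at the ester oxygen, alongside a number 16 percentage points higher from compound 2 to compound 3 (beyond the scatter). Among the non-aromatic esters, the change of group gives no readable difference, with a number 3 percentage points higher from compound 2 to compound 4 (within the scatter). Double-bond geometry, tested here only on the ethyl ester, also gives no readable difference, with a number 1 percentage points lower from compound 1 to compound 4 (within the scatter), and this comparison isolates a single feature: the fact that compounds 1 and 4 differ only in the configuration as drawn.

From the compounds shown here alone, whether the step follows the phenyl ring itself or the larger ester group remains open, and a longer chain such as hexyl or a carboxylic acid in place of the ester would help separate the two. With the benzyl ester only the Z double bond is shown, so the effect of the E form on that ester is also unresolved.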